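Fluoro for methyl on a second nitro-bearing core

The compounds below may be only part of what the source reports. "The series", "measured", "known", "first", "only" and "open" are said of these compounds alone.

Of the compounds shown here, three have been tested in a functional assay on MOLT-4 cells (Homo sapiens) for cytotoxicity, with a stated time of 72 h; a lower number here means a stronger inhibitor, a higher number a weaker inhibitor. Compound 1 `Cc1ccc(/C=C2\CCC/C(=C\c3ccccc3[N+](=O)[O-])C2=O)cc1` gives 7520 nM. Compound 2 `Cc1ccc(/C=C2\CCC/C(=C\c3ccc([N+](=O)[O-])cc3)C2=O)cc1` gives 8440 nM, and these two numbers lie within the scatter of each other. The two share the same atoms joined differently, and the difference between the two cores is not broken down here. Compound 3 `O=C1/C(=C/c2ccc(F)cc2)CCC/C1=C\c1ccccc1[N+](=O)[O-]` gives 1870 nM. Among the compounds with values here, from compound 1 to compound 3 the only change is fluoro in place of methyl on an aromatic carbon, and it brings a 4.0-fold lower number from compound 1 to compound 3 (0.60 log units; beyond the scatter).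

Compound 4 `O=C1/C(=C/c2ccc(F)cc2)CCC/C1=C\c1ccc([N+](=O)[O-])cc1` has not yet been measured. It differs from compound 2 by fluoro in place of methyl on an aromatic carbon, which is the same change that separates compound 1 from compound 3, made on the other core. Because the step of a 4.0-fold lower number from compound 1 to compound 3 (0.60 log units; beyond the scatter) was seen once on the neighbouring core, a step of similar size is expected from compound 2 to compound 4, namely a 3.8-fold lower number from compound 2 to compound 4 (0.58 log units; beyond the scatter). On that basis compound 4 is estimated to give 2200 nM in this assay, with a range from 900 nM to 6000 nM allowing that a single observed step may not carry over exactly.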

Compound 4, half-maximal inhibitory concentration: 17100 nM
Compound 4: middle estimate off by 7.8-fold (0.89 log units), on the low side; the whole stated range lies below it.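

On the core of compound 2, fluoro in place of methyl on an aromatic carbon gives a 2.0-fold higher number from compound 2 to compound 4 (0.31 log units; beyond the scatter), so the number moves in the opposite direction from the one seen on the core of compound 1. The two results for this single change clearly disagree in this assay: the same change on two cores in this assay, a 4.0-fold lower number (0.60 log units; beyond the scatter) from compound 1 to compound 3 and a 2.0-fold higher number (0.31 log units; beyond the scatter) from compound 2 to compound 4, 8.1-fold (0.91 log units) apart, beyond the scatter of two such steps

In this series, then, a step seen on one core is not a safe guide to the same change on the other, although these two pairs alone do not reveal which difference between the cores lies behind the disagreement or why it arises.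

Going by these compounds, it remains open whether the split between the cores is confined to the swap from methyl to fluoro, or whether a chloro or methoxy group on the same aromatic carbon of both cores would also behave differently. An amine in place of the nitro group on each core would be a further way to ask how much that group matters to the outcome.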